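This account rests on a few compounds, and the source may have more. Where it says the series, first, only, none or still open, it means among the compounds named here.

In a functional assay on BT-474 cells (Homo sapiens) for inhibition, with a stated time of 72 h (a lower number here means a stronger inhibitor of growth, a higher number a weaker inhibitor of growth), compound 1 (`O=C(c1cc(-n2ccc3ccccc32)c(O)cc1O)N1Cc2ccccc2C1`) gives 7250 nM as its growth-inhibition concentration. Among the measured compounds shown here, the only other measured compound, compound 2 (`Cc1ccc2c(ccn2-c2cc(C(=O)N3Cc4ccccc4C3)c(O)cc2O)c1`), gives 7070 nM, and the two values lie within the scatter of each other. Compound 3 (`O=C(c1cc(Nc2ccc(Cl)cc2Cl)c(O)cc1O)N1Cc2ccccc2C1`) has not yet been measured. It keeps the core of compound 1 but has (2,4-dichlorophenyl)amino in place of 1H-indol-1-yl on an aromatic carbon. For the measured compounds named here, the single measured step (a 1.0-fold lower number from compound 1 to compound 2 (0.01 log units; within the scatter)) is methyl in place of hydrogen on an aromatic carbon, and it stays within the scatter. That step leaves 1H-indol-1-yl in place, so it gives only weak guidance on replacing the whole group. No step beyond the scatter is therefore expected in this assay, and the range is kept wide. The estimated change is small (a 1.5-fold lower number from compound 1 to compound 3 (0.16 log units; within the scatter)). The expected value for compound 3 is 5000 nM, within an estimated range of 1500 nM to 15000 nM.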

Compound 3, concentration for 50% growth inhibition: 6310 nM
Beside the measured number, compound 3's estimate is 1.3-fold (0.10 log units) below it; the range from low to high includes it.
By their numbers in this assay, from the lowest: compounds 3, 2 and 1 (each within the scatter of the next).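

In this assay, putting (2,4-dichlorophenyl)amino in place of 1H-indol-1-yl on the aromatic carbon gives a 1.1-fold lower number from compound 1 to compound 3 (0.06 log units; within the scatter). The earlier step only added a methyl to the 1H-indol-1-yl group, whereas this one exchanges the whole group at this position and still stays within the scatter. The two groups differ in their rings, in chlorine and in hydrogen-bond donors, yet the number does not separate from that of compound 1, and no measurement shown here explains this.

Going by these compounds, whether any group at this position can move the number beyond the scatter remains open. The compounds shown do not say how a much smaller group, such as an amine or a carboxylic acid, or a saturated ring such as morpholine, would read in this assay at this aromatic carbon.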